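Notes on cyano in place of bromo in the series

The compounds below may be only part of what the source reports. "The series", "measured", "known", "first", "only" and "open" are said of these compounds alone.

Of the compounds shown here, two on a shared core have been measured so far, compound 1 `Cc1cc(S(N)(=O)=O)ccc1NC(=O)COc1ccc(Cl)cc1NC(=O)c1ccccc1C` and compound 2 `Cc1cc(S(N)(=O)=O)ccc1NC(=O)COc1ccc(Cl)cc1NC(=O)c1cc(Cl)cc(Br)c1`. In a functional assay on C8166 cells (Homo sapiens) for cytotoxicity, read by MTT assay (on this read-out lower numbers stand for higher toxicity in this test and higher numbers for lower toxicity in this test), compound 1 gives 67300 nM and compound 2 gives 114000 nM. These two numbers lie within the scatter of each other, so compound 2 stands level with compound 1 on the data available.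

Compound 3 `Cc1cc(S(N)(=O)=O)ccc1NC(=O)COc1ccc(Cl)cc1NC(=O)c1cc(Cl)cc(C#N)c1` carries cyano in place of bromo on an aromatic carbon, meta to a chloro group and meta to a large group: cyano in place of bromo on an aromatic carbon. For the measured compounds named here, no measured pair isolates this exchange. Going by the values given here, the only step that bears on it is a 1.7-fold higher number from compound 1 to compound 2 (0.23 log units; within the scatter), where 3-bromo-5-chlorophenyl replaces 2-methylphenyl on a carbonyl carbon. That step changes the whole group on the carbonyl carbon and still stays within the scatter, so one evidence-poor comparison is all that supports the expectation here. No step beyond the scatter is expected in this assay, and no direction can be assigned. The expected step is a 1.1-fold lower number from compound 2 to compound 3 (0.06 log units; within the scatter). Compound 3 is estimated at 100000 nM, with an expected range from 50000 nM to 200000 nM.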

Compound 3, half-maximal cytotoxic concentration: 131000 nM
For compound 3 the middle estimate is 1.3-fold (0.12 log units) below the measured one; measured number inside the range.
By their numbers in this assay, from the lowest: compounds 1, 2 and 3 (each within the scatter of the next).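

The bromo-to-cyano exchange on this aromatic carbon, meta to a chloro group and meta to a large group, can now be read directly in this assay as a 1.1-fold higher number from compound 2 to compound 3 (0.06 log units; within the scatter) and so does not separate the two groups in this test. Exchanging the whole group on the carbonyl carbon, 3-chloro-5-cyanophenyl in place of 2-methylphenyl, gives a 1.9-fold higher number from compound 1 to compound 3 (0.29 log units; within the scatter) and leaves compound 3 level with compound 1, so the three groups on this carbonyl carbon stand together on these numbers, with no exception among the compounds shown. No data on any property of bromo or cyano accompany these numbers, and nothing shown explains why the exchange leaves the read-out level.

As far as these compounds go, whether an amine or a carboxylic acid in place of cyano on this aromatic carbon would give a step beyond the scatter remains open. Also open, from the compounds shown here alone, is what a methoxy group would do in place of the chloro group that compound 2 and compound 3 share on this ring, and whether any change on this ring can move this read-out at all.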